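Replacing the carboxy group of compound 3

The source may report more compounds than this note shows. Statements on the series, on what has been measured and on what is new or still open speak of the compounds shown alone.

In a functional assay on HeLa cells (Homo sapiens) for cytotoxicity, read by neutral red uptake, with a stated time of 3 days (a lower number here means a stronger inhibitor, a higher number a weaker inhibitor), three compounds sharing one core have been measured. Compound 1 (`Cc1c(F)c(N)c2c(=O)cc(-c3ccc(N)c(F)c3)oc2c1F`) gives > 100000 nM, which is a limit of the assay. Compound 2 (`Nc1ccc(-c2cc(=O)c3c(N)c(F)c(Cl)c(F)c3o2)cc1F`) gives > 100000 nM, again a limit. Compound 3 (`Nc1ccc(-c2cc(=O)c3c(N)c(F)c(C(=O)O)c(F)c3o2)cc1F`) gives > 100000 nM, also a limit, so it stands without a number of its own.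

Compound 4 (`CCCCCC(=O)OCc1c(F)c(N)c2c(=O)cc(-c3ccc(N)c(F)c3)oc2c1F`) carries ((pentylcarbonyl)oxy)methyl in place of carboxy on an aromatic carbon, ortho to two fluoro groups: ((pentylcarbonyl)oxy)methyl in place of carboxy on an aromatic carbon. Going by the values given here, three measured steps bear on this change, as each exchanges the group on that same carbon: a step that the two limits leave unreadable from compound 1 to compound 2, a step that the two limits leave unreadable from compound 1 to compound 3 and a step that the two limits leave unreadable from compound 2 to compound 3. None of them has a readable size, and the three compounds share one result: the limit of > 100000 nM in this assay, at which 3 of the 3 values shown sit. The entering group also differs from methyl, chloro and carboxy alike, so these steps do not reach it directly.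

With no size to carry over, the data support no expected change beyond the scatter, in either direction. The expected step is an at least 1.2-fold lower number from compound 3 to compound 4 (0.09 log units; that floor lies within the scatter). Compound 4 is estimated at 80000 nM, with an expected range from 25000 nM to 150000 nM, and it may well be reported only as a limit.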

Compound 4, half-maximal inhibitory concentration: 34000 nM
Compound 4: the middle estimate sits 2.4-fold (0.37 log units) above what was measured; measured number inside the range.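

In this assay, the aromatic carbon ortho to two fluoro groups now yields a first readable change, with the ((pentylcarbonyl)oxy)methyl group giving an at least 2.9-fold lower number from compound 3 to compound 4 (0.46 log units; beyond the scatter). Set against the chloro group on that carbon, the same group gives an at least 2.9-fold lower number from compound 2 to compound 4 (0.46 log units; beyond the scatter), and where (pentylcarbonyl)oxy takes the place of hydrogen on a saturated chain carbon bound to an aromatic carbon, the result is an at least 2.9-fold lower number from compound 1 to compound 4 (0.46 log units; beyond the scatter). The position is therefore able to move the read-out in this assay, whereas the methyl, chloro and carboxy compounds could not be told apart, and only compound 4 stands clear of the limit that the other three share: the limit of > 100000 nM in this assay, at which 3 of the 4 values shown sit.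

What the compounds shown leave open is whether the change goes with the ester link or with the length of its chain, a question that a hydroxymethyl group, a shorter acyl chain or an amide on the same carbon would bear on. On these data alone, how far compound 4 truly lies from the other three also stays open, for each of the three steps gives only a floor set by a limit.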